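A few compounds are considered here, and "the series" means these few. Any claim that something is new, unique, unknown or untested is made for them only; others in the source may bear on it.

Compound 1 `COC(=O)N[C@H](C(=O)N1CCC[C@H]1C(=O)Nc1ccc([C@@H]2CC[C@@H](c3ccc(NC(=O)[C@@H]4CCCN4C(=O)[C@@H](NC(=O)OC)[C@@H](C)OC)cc3)N2c2ccc(F)cc2)cc1)[C@@H](C)OC` is the less lipophilic of the two measured compounds. In a physicochemical assay for lipophilicity, read by HPLC, at pH 7.4 (on this read-out higher numbers stand for higher lipophilicity and lower numbers for lower lipophilicity), compound 1 gives 3, while compound 2 `COC(=O)N[C@H](C(=O)N1CCC[C@H]1C(=O)Nc1ccc([C@@H]2CC[C@@H](c3ccc(NC(=O)[C@@H]4CCCN4C(=O)[C@@H](NC(=O)OC)C(C)C)cc3)N2c2ccc(C(F)(F)F)cc2)cc1)C(C)C` gives 4.8, a gap beyond the usual scatter.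

Compound 3 `COC(=O)N[C@H](C(=O)N1CCC[C@H]1C(=O)Nc1ccc([C@H]2CC[C@H](c3ccc(NC(=O)[C@@H]4CCCN4C(=O)[C@@H](NC(=O)OC)[C@@H](C)OC)cc3)N2c2ccc(F)cc2)cc1)[C@@H](C)OC` has not yet been measured. It differs from compound 1 only in how two ring carbons are configured: the two compounds have the same atoms and bonds and differ only in configuration as drawn: 2 of 8 stereo elements differ; a stereocentre at a saturated ring carbon is drawn S in compound 1 and R in compound 3; a stereocentre at a saturated ring carbon is drawn S in compound 1 and R in compound 3. Nothing is added or removed, so no step beyond the scatter is expected; the step of no change at the digits printed from compound 1 to compound 3 (within the scatter) is estimated as essentially flat. Compound 3 is therefore expected to give about 3, within a range from 2.6 to 3.4.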

Compound 3, distribution coefficient: 3
The estimate for compound 3 equals the measured number at the digits printed, within the range that was stated.
By their numbers in this assay, from the lowest: compounds 1 and 3 (each within the scatter of the next); then compound 2.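

In this assay, changing the configuration at the two ring carbons gives no change at the digits printed from compound 1 to compound 3 (within the scatter), so this read-out does not separate the two arrangements. Compounds 1 and 2 differ in more than one place, and their gap points to no single change; this pair isolates one kind of change, which makes it a direct comparison: the fact that compounds 1 and 3 differ only in the configuration as drawn

Still open, on these data alone, is whether the two ring carbons stay equally silent in this assay on the core of compound 2. Also open, as far as these compounds go, is how a carboxylic acid or an amine on the shared core would read.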